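This account rests on a few compounds, and the source may have more. Where it says the series, first, only, none or still open, it means among the compounds named here.

Measured compounds and their values in a functional assay on 786-0 cells (Homo sapiens) for inhibition, read by sulforhodamine B assay, with a stated time of 48 h, tested at 0.01 uM; a higher number here means a weaker effect of the compound at the concentration tested, a lower number a stronger effect:

Compound 1 `COc1cc(Cl)cc(-c2nn(-c3cccc(NC(=O)Nc4ccc(Cl)c(C(F)(F)F)c4)c3)cc2-c2ccncc2)c1`: 96%
Compound 2 `COc1cc(Cl)cc(-c2nn(-c3cccc(NC(=O)Nc4ccc(Cl)c(Cl)c4)c3)cc2-c2ccncc2)c1`: 100%
Compound 3 `COc1cc(Cl)cc(-c2nn(-c3cccc(NC(=O)Nc4cccc(C(F)(F)F)c4)c3)cc2-c2ccncc2)c1`: 99%

The three compounds share one core and differ only in the aryl group carried on the urea. All three sit close together: the step of a number 4 percentage points higher from compound 1 to compound 2 (within the scatter) and the step of a number 3 percentage points higher from compound 1 to compound 3 (within the scatter) are small, and so is the step of a number 1 percentage points lower from compound 2 to compound 3 (within the scatter). Compound 3 has the second highest of the three numbers, nearest to compound 2 and furthest from compound 1, but neither gap reaches beyond the scatter, so no order among them can be read from these numbers.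

Compound 4 `COc1cc(Cl)cc(-c2nn(-c3cccc(NC(=O)c4cccc(C(F)(F)F)c4)c3)cc2-c2ccncc2)c1` is not yet measured. Its change from compound 3 is 3-(trifluoromethyl)phenyl in place of (3-(trifluoromethyl)phenyl)amino on a carbonyl carbon, which turns the urea into an amide. For the measured compounds named here, none of the measured steps touches that part of the molecule; they all exchange one aryl group for another, and each stayed within the scatter. Going by the values given here, there is no measured step that speaks to the removal of the amino group, so the only guide is that every variation seen so far left the read-out essentially unchanged. For compound 4 the expected step is therefore a number 1 percentage points lower from compound 3 to compound 4 (within the scatter), that is, none beyond the scatter. Compound 4 is estimated at 98%, with a range from 90% to 105%.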

Compound 4, a percentage reported as activity, at one concentration (the size of the read-out at that concentration, not a potency): 99%
Compound 4: the middle estimate sits 1 percentage points below what was measured; low and high end bracket the measured number.
By their numbers in this assay, from the lowest: compounds 1, 3, 4 and 2 (each within the scatter of the next).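

For the compounds shown here, replacing the urea with an amide removes the amino group, the part of the leaving group counted as a hydrogen-bond donor, and this is the first change at the carbonyl carbon rather than on the outer aryl group; in this assay the result is no change at the digits printed from compound 3 to compound 4 (within the scatter). The comparisons with the other two ureas give a number 1 percentage points lower from compound 2 to compound 4 (within the scatter) and a number 3 percentage points higher from compound 1 to compound 4 (within the scatter), so in this assay the amide cannot be told apart from any of the three ureas, and at this single concentration the amino group shows no measurable contribution to the read-out. No measurement at hand explains this outcome.

All four compounds sit in one narrow band at one concentration, which leaves open whether the urea and the amide would separate at a concentration where the read-out moves clearly away from this band. Also open, as far as these compounds go, is how the compound would read with a methylene group or an ether oxygen in place of the amino group on the carbonyl carbon.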